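Solubility of a Biaryl Acylurea Series: Predicting a Trifluoroethoxy Analogue

This account rests on a few compounds, and the source may have more. Where it says the series, first, only, none or still open, it means among the compounds named here.

Measured so far:
Compound 1, `COc1ccccc1C(=O)NC(=O)Nc1ccc(-c2ccccc2)c(C(F)(F)F)c1`: in a physicochemical assay for solubility (a lower number here means a less soluble compound, a higher number a more soluble compound), compound 1 gives < 1 ug/mL, a limit of the assay rather than a number.
Compound 2, `COc1ccccc1C(=O)NC(=O)Nc1ccc(-c2ccccc2)c(C(C)C)c1`: in this assay compound 2 gives < 1 ug/mL, again a limit and not a number.
Compound 3, `COc1ccccc1C(=O)NC(=O)Nc1ccc(-c2nccs2)c(C(F)(F)F)c1`: in this assay compound 3 gives 1.1 ug/mL.

Going by the values given here, compound 3 thus stands alone as the only measured number in this assay; the other two results sit at the limit of < 1 ug/mL in this assay, at which 2 of the 3 values shown sit. The step of an at least 1.1-fold higher number from compound 1 to compound 3 (0.04 log units; that floor lies within the scatter) is the only readable one, and its floor is small. The step that the two limits leave unreadable from compound 1 to compound 2 cannot be sized.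

Compound 4, `COc1ccccc1C(=O)NC(=O)Nc1ccc(OCC(F)(F)F)c(C(F)(F)F)c1`, is not yet measured. It differs from compound 3 by 2,2,2-trifluoroethoxy in place of 1,3-thiazol-2-yl on an aromatic carbon. Among the compounds with values here, no measured step swaps an aromatic ring for a chain at this position, so the expectation rests on the fact that every compound so far sits at or just above the limit of this assay. Compound 4 is therefore expected to behave much like compound 3, with a step of a 1.1-fold higher number from compound 3 to compound 4 (0.04 log units; within the scatter) that lies within the scatter. For compound 4 the estimate in this assay is 1.2 ug/mL, with a range from 0.3 ug/mL to 5 ug/mL, and a real chance that only a limit is reported.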

Compound 4, solubility: < 1 ug/mL
Compound 4 gave a limit, no number; the forecaster's own chance of this, stated with the estimate: 45%; middle value at least 1.2-fold (0.07 log units) away from the limit.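

Going by these compounds alone, compound 4 is the first compound here with no ring at this position, which is ortho to a trifluoromethyl group and para to a large group. On these data alone, replacing the ring with a chain gives an at least 1.1-fold lower number from compound 3 to compound 4 (0.04 log units; that floor lies within the scatter), so the change shows no gain in this assay, but the size of the drop remains unknown: only its floor can be read, and the true value of compound 4 could lie close to that of compound 3 or well under it. The step from compound 1 to compound 4 has a limit at both ends and cannot be read, and with this result an open chain joins the aromatic rings in crowding the bottom of the measurable range: the limit of < 1 ug/mL in this assay, at which 3 of the 4 values shown sit.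

The compounds shown leave open whether a group such as an amine or a carboxylic acid at this position would give a number clearly above the limit in this assay. They also leave open how compound 1, compound 2 and compound 4 rank against one another, as none of the three has a number.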